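Series notes: from compound 2 to compound 3

The source may hold more compounds than are shown below. What is called first, only, known or untested is meant among the compounds shown, and "the series" means these compounds.

Measured so far:
compound 1 `C=CC(=O)N1CC(NC(=O)Cn2c(C)c(C(=O)N3CCc4c(cccc4OC)C3)c3cc(Cl)cc(C)c32)C1` — 1.67 h
compound 2 `C=CC(=O)N1CC(NC(=O)Cn2cc(C(=O)N3CCc4c(Cl)cccc4C3)c3cc(Br)ccc32)C1` — 1.67 h

In a physicochemical assay for pharmacokinetics, read by LC-MS, in phosphate buffer, at pH 7.4, in the presence of a further agent that is not named here (a lower number here means that the compound disappears faster, a higher number that the compound lasts longer), compound 1 gives 1.67 h. Compound 2 gives 1.67 h in this assay, level with compound 1 at the digits shown; the two readings fall within the scatter of this kind of measurement, so no order between them can be read, and no step between measured compounds is available. Both share the core of compound 2 with its reactive terminal group and the same amide linker.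

Compound 3 `C=CC(=O)N1CC(NC(=O)Cn2cc(C(=O)N3CCc4c(cccc4OC)C3)c3cc(Br)ccc32)C1` has not yet been measured. It differs from compound 2 by methoxy in place of chloro on an aromatic carbon. Among the measured compounds shown here, compound 1, which also carries a methoxy group on its core, gives a reading level with that of compound 2, and nothing among the measured pairs points to a move in either direction for this kind of change. The step is therefore expected to be none beyond the scatter; the expected step of a 1.0-fold higher number from compound 2 to compound 3 (0.01 log units; within the scatter) is small. Compound 3 is estimated to give 1.7 h in this assay, with a range from 0.9 h to 3.3 h.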

Compound 3, half-life: 1.67 h
Compound 3: the middle estimate sits 1.0-fold (0.01 log units) above what was measured; measured number inside the range.
By their numbers in this assay, from the lowest: compounds 1, 2 and 3 (each within the scatter of the next).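

The series now has its first pair of compounds that differ in one place: in this assay, methoxy in place of chloro on an aromatic carbon, ortho to a fused ring and meta to a fused ring, gives no change at the digits printed from compound 2 to compound 3 (within the scatter). At this position, the read-out therefore does not separate the two groups, although the entering methoxy counts one hydrogen-bond acceptor and the leaving chloro none. Nothing at hand bears on why the half-life stays level here.

Going by these compounds, whether this aromatic carbon can influence the read-out at all remains open, since this single pair spans only chloro and methoxy, and an amine or a carboxylic acid on the same carbon could either stay level or depart from it. Among the compounds shown, no one-place pair addresses the reactive terminal group or the amide linker, so the dependence of the half-life on those parts also remains open.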